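The source may report more compounds than this note shows. Statements on the series, on what has been measured and on what is new or still open speak of the compounds shown alone.

The two compounds measured so far and their values in a functional assay on HT-29 cells (Homo sapiens) for cytotoxicity, read by MTT assay, with a stated time of 24 h, tested at 80 ug/mL; on this read-out lower numbers stand for a weaker effect and higher numbers for a stronger effect at the one concentration tested:

Compound 1, `Cn1cnnc1SCC(=O)Nc1ccc(-c2nc(-c3ccccc3)c(-c3ccccc3)n2C)cc1`, gives 88%.
Compound 2, `Cn1ccnc1SCC(=O)Nc1ccc(-c2nc(-c3ccccc3)c(-c3ccccc3)n2C)cc1`, gives 69.4%.

Compound 2 stands lowest of the two numbers; its nearest neighbour is compound 1, and the step of a number 18.6 percentage points lower from compound 1 to compound 2 (beyond the scatter) puts it beyond the scatter, with 1-methyl-1H-imidazol-2-yl in place of 4-methyl-4H-1,2,4-triazol-3-yl on a sulfur.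

Compound 3, `CCN1CCN(CC(=O)Nc2ccc(-c3nc(-c4ccccc4)c(-c4ccccc4)n3C)cc2)CC1`, has not yet been measured in this assay. It differs from compound 2 as follows: 4-ethylpiperazin-1-yl in place of (1-methyl-1H-imidazol-2-yl)sulfanyl on a saturated chain carbon bound to a carbonyl carbon. The whole sulfur-linked five-membered ring leaves and a six-membered saturated ring enters on the saturated chain carbon bound to the carbonyl carbon.

Among the compounds with values here, only one measured step exists, and it is of another kind: swapping one five-membered ring for another on the sulfur. It shows that changes in this part of the molecule can move the read-out modestly, but it does not show what removing the sulfur-linked ring altogether does. The expectation for compound 3 therefore rests on little, and the step of a number 9.4 percentage points lower from compound 2 to compound 3 (within the scatter) is estimated with a wide range. Compound 3 is estimated at 60%, between 30% and 88%.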

Compound 3, a percentage reported as activity, at one concentration (the size of the read-out at that concentration, not a potency): 51.2%
The estimate for compound 3 lay 8.8 percentage points above the measured number; measured number inside the range.
By their numbers in this assay, from the lowest: compound 3; then compound 2; then compound 1.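

In this assay, the sulfur-linked five-membered ring on the saturated chain carbon bound to a carbonyl carbon proves replaceable by a group of a quite different kind, and putting 4-ethylpiperazin-1-yl there gives a number 18.2 percentage points lower from compound 2 to compound 3 (beyond the scatter) when the imidazole compound is the starting point. Starting from the triazole compound instead, the same kind of exchange gives a number 36.8 percentage points lower from compound 1 to compound 3 (beyond the scatter) and spans the widest gap among the three compounds, so the earlier ring swap on the sulfur was not the only change here that moves the read-out, and both sulfur-linked compounds stand above the piperazine compound. Nothing available here explains why the number drops with this change.

The exchange alters several things at once, since the sulfur leaves, a five-membered aromatic ring gives way to a six-membered non-aromatic one, and an ethyl group arrives, so the compounds shown cannot separate these parts. On these data alone, whether morpholin-4-yl, a plain piperazin-1-yl without the ethyl group, or a phenyl ring on the same sulfur would read closer to the triazole compound or to the piperazine compound remains open.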